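Adding a Methyl to the Ketone-Bearing Ring

A few compounds are considered here, and "the series" means these few. Any claim that something is new, unique, unknown or untested is made for them only; others in the source may bear on it.

Measured compounds:
compound 1, `COc1ccc(C(=O)/C=C/c2cc(-c3cc(OC)c(OC)c(OC)c3)n3nc(-c4ccccc4)cc3n2)cc1`, 14600 nM
compound 2, `COc1cc(C(=O)/C=C/c2cc(-c3cc(OC)c(OC)c(OC)c3)n3nc(-c4ccccc4)cc3n2)cc(OC)c1OC`, 20500 nM
compound 3, `COc1cc(-c2cc(/C=C/C(=O)c3ccc(C)cc3)nc3cc(-c4ccccc4)nn23)cc(OC)c1OC`, 19400 nM

All three share one core and differ only in the aryl group attached to the carbonyl carbon. In a functional assay on A549 cells (Homo sapiens) for antiproliferative activity, read by MTT assay, with a stated time of 24 h (a lower number here means a stronger inhibitor, a higher number a weaker inhibitor), compound 3 stands close to both of its neighbours: the step of a 1.1-fold lower number from compound 2 to compound 3 (0.02 log units; within the scatter) and the step of a 1.3-fold higher number from compound 1 to compound 3 (0.12 log units; within the scatter) both lie within the scatter, so no ordering among the three can be claimed.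

Compound 4, `COc1cc(-c2cc(/C=C/C(=O)c3ccc(C)c(C)c3)nc3cc(-c4ccccc4)nn23)cc(OC)c1OC`, is the next step. Its change from compound 3 is methyl in place of hydrogen on an aromatic carbon.

Among the compounds with values here, no measured step adds a methyl to a hydrogen-bearing aromatic carbon of this ring. What the measured steps do show is that swapping the whole aryl group on the carbonyl carbon leaves the number essentially unchanged: a 1.4-fold higher number from compound 1 to compound 2 (0.15 log units; within the scatter), a 1.3-fold higher number from compound 1 to compound 3 (0.12 log units; within the scatter) and a 1.1-fold lower number from compound 2 to compound 3 (0.02 log units; within the scatter) are each within the scatter. A single extra methyl is a smaller change than any of those swaps, so compound 4 is expected to show no step beyond the scatter, a 1.0-fold lower number from compound 3 to compound 4 (0.01 log units; within the scatter).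

Compound 4 is therefore estimated at 19000 nM in this assay, with a range from 9000 nM to 40000 nM.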

Compound 4, half-maximal inhibitory concentration: 10600 nM
Compound 4: the middle estimate sits 1.8-fold (0.25 log units) above what was measured; the measured number falls inside the stated range.
By their numbers in this assay, from the lowest: compounds 4, 1, 3 and 2 (each within the scatter of the next).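

In this assay, within the data shown here, adding a methyl to the 4-methylphenyl ring, on an aromatic carbon ortho to the existing methyl group, gives a 1.8-fold lower number from compound 3 to compound 4 (0.26 log units; within the scatter) and so shows for the first time what this single addition does: the step is larger than those among the earlier compounds, yet it stays within the scatter. The 3,4-dimethylphenyl group also stays within the scatter of both groups bearing methoxy on the carbonyl carbon, with a 1.9-fold lower number from compound 2 to compound 4 (0.29 log units; within the scatter) and a 1.4-fold lower number from compound 1 to compound 4 (0.14 log units; within the scatter) as its steps, so this position tolerates the extra methyl in this assay, but the four compounds still cannot be placed in a firm order. No measurement shown here offers an explanation for these numbers.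

The compounds shown carry only hydrogen or methyl at this position, so it remains open whether an amine, a hydroxyl group or a longer chain such as propyl would produce a step beyond the scatter. As far as these compounds go, it is also open whether the same added methyl would give a similar step on a 3-methylphenyl ring lacking the 4-methyl group, or on a different aryl group.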